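This account rests on a few compounds, and the source may have more. Where it says the series, first, only, none or still open, it means among the compounds named here.

Measured so far in an ADME assay on HepG2 cells (Homo sapiens) for cytotoxicity, with a stated time of 72 h; a lower number here means that less compound is needed, a higher number that more compound is needed for the effect:
Compound 1 `O=C(Nc1ccc(O)c(-c2nc3ccccc3s2)c1)c1cc([N+](=O)[O-])ccc1Cl`: > 25000 nM
Compound 2 `O=C(Nc1cccc(-c2nc3ccccc3s2)c1)c1cc([N+](=O)[O-])ccc1Cl`: > 27000 nM
Compound 3 `O=C(Nc1cccc(-c2nc3ccccc3o2)c1)c1cc([N+](=O)[O-])ccc1Cl`: > 25000 nM

Each of these entries is a limit of the assay and not a number. Compound 2 therefore has no exact place in the series: compound 2 stands at > 27000 nM, which is a limit. Compound 4 `Cc1c(NC(=O)c2cc([N+](=O)[O-])ccc2Cl)cccc1-c1nc2ccccc2s1` has not yet been measured. It differs from compound 2 by a single change, methyl in place of hydrogen on an aromatic carbon, ortho to a 1,3-benzothiazol-2-yl group.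

Two measured steps start from or lead to compound 2. One is a step that the two limits leave unreadable from compound 1 to compound 2, where hydrogen replaces hydroxy on an aromatic carbon. The other is a step that the two limits leave unreadable from compound 2 to compound 3, where 1,3-benzoxazol-2-yl replaces 1,3-benzothiazol-2-yl. Neither step has a readable size, so neither can set the size of the new one. Still, neither change brought a measurable number into this assay, and the methyl change is small. No step beyond the usual scatter is therefore expected, in either direction, and another limit is the likeliest result. The expected change is a step that the limit leaves unreadable from compound 2 to compound 4. The estimate for compound 4 is 30000 nM, with an expected range from 12000 nM to 60000 nM.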

Compound 4, half-maximal effective concentration: > 25000 nM
Compound 4: no number, only a limit (the forecaster's own chance of this, stated with the estimate: 85%); the middle value is on the limit's open side.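

In this assay compound 4 gives > 25000 nM, which is a limit of the assay and not a number. Going by these compounds alone, compound 2 also stands at a limit, > 27000 nM, so no step between compound 2 and compound 4 can be read. The compounds shown leave open at what concentration, if any, each reaches its half-maximal effect in this assay.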